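The source may hold more compounds than are shown below. What is called first, only, known or untested is meant among the compounds shown, and "the series" means these compounds.

The series was examined in an assay on HEK-293T cells for inhibition of phospholipase A and acyltransferase 5 (Homo sapiens), with stated times of 30 min and 20 min; on this read-out higher numbers stand for weaker inhibition and lower numbers for stronger inhibition. Compound 1 `O=C(CCc1ccc(Cl)cc1)C(=O)NCCCCc1ccccc1` carries an open-chain amide, and in this assay compound 1 gives 200 nM. Compound 2 `O=C(CCc1ccccc1)[C@H](F)C(=O)NCc1ccccc1` returns only a limit of this assay, and in it compound 2 gives > 10000 nM. Compound 3 `O=C(CCc1ccc(Cl)cc1)C(=O)N1CCCCC1`, whose amide nitrogen belongs to a piperidin-1-yl ring, likewise reaches only a limit, and in this assay compound 3 gives > 10000 nM. Compound 3 thus stands at the limit of > 10000 nM in this assay, at which 2 of the 3 values shown sit, with no number of its own to anchor a comparison, and no pair among these compounds differs in a single place, so no measured step exists.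

Compound 4 `O=C(CCc1ccc(Cl)cc1)C(=O)N1CCOCC1` has not yet been measured; it differs from compound 3 by morpholin-4-yl in place of piperidin-1-yl on a carbonyl carbon, a swap of one saturated six-membered ring for another on the same carbonyl carbon. Compound 3 already sits at the limit of this assay. The estimated step of a number no higher from compound 3 to compound 4 (the limit leaves the size open) is expected to be none beyond the scatter. Compound 4 is therefore expected to give about 10000 nM in this assay, within a range of 3000 nM to 30000 nM, most likely again reported only as a limit.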

Compound 4, half-maximal inhibitory concentration: > 10000 nM
Compound 4 ended at the assay's limit; the forecaster's own chance of this, stated with the estimate: 75%; the middle value sits exactly at the limit.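

For the compounds shown here, compound 3 and compound 4 both stop at a limit in this assay and carry no number of their own, so no step between them can be read: the limit of > 10000 nM in this assay, at which 3 of the 4 values shown sit. The compounds shown leave open whether morpholin-4-yl and piperidin-1-yl on this carbonyl carbon differ at all in this assay and, if they do, by how much.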